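A few compounds are considered here, and "the series" means these few. Any claim that something is new, unique, unknown or untested is made for them only; others in the source may bear on it.

Measured so far:
Compound 1, `COc1cc(-n2ncnc2-c2cccc([N+](=O)[O-])c2)cc(OC)c1OC`, in a functional assay on Jurkat cells (Homo sapiens) for antiproliferative activity, read by MTT assay, with a stated time of 72 h (on this read-out lower numbers stand for stronger inhibition and higher numbers for weaker inhibition), gives only a limit, > 10000 nM.
Compound 2, `COc1ccccc1-c1ncnn1-c1cc(OC)c(OC)c(OC)c1`, in this assay gives only a limit, > 10000 nM.
Compound 3, `COc1cc(-c2ncnn2-c2ccc(Cl)c(Cl)c2)cc(OC)c1OC`, in this assay gives only a limit, > 10000 nM.

Compound 3 therefore stands, with the other two, at the limit of > 10000 nM in this assay, at which 3 of the 3 values shown sit. No measured step separates any pair of these three compounds, and no order of potency among them can be stated from the numbers shown.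

Compound 4, `COc1cc(-c2ncnn2-c2cccc(F)c2)cc(OC)c1OC`, differs from compound 3 in one place: 3-fluorophenyl in place of 3,4-dichlorophenyl on an aromatic nitrogen.

For the measured compounds named here, no measured step of this kind exists, so the size of the change from compound 3 to compound 4 in this assay cannot be taken from data. With compound 3 sitting at a limit, only a move into the measurable range would register at all, and no step beyond the usual scatter is expected in either direction.

Compound 4 is expected to give about 15000 nM, within a range of 5000 nM to 50000 nM, most probably reported again as a limit rather than a number. This estimate corresponds to an expected step that the limit leaves unreadable from compound 3 to compound 4, taken as lying within the scatter.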

Compound 4, half-maximal inhibitory concentration: > 10000 nM
Compound 4: a limit, no number (the forecaster's own chance of this, stated with the estimate: 75%); the middle value is on the limit's open side.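

Compound 3 and compound 4 both give only a limit in this assay, and no step can be read between them. The series as shown stands as follows: the limit of > 10000 nM in this assay, at which 4 of the 4 values shown sit.

The compounds shown leave open which change on the shared core, if any, would bring a value into the measurable range.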